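Chloro at a second benzyl position in the benzothiazole urea series

A few compounds are considered here, and "the series" means these few. Any claim that something is new, unique, unknown or untested is made for them only; others in the source may bear on it.

Compound 2 `CC1CCN(Cc2ccc3nc(NC(=O)N/N=C/c4cn(Cc5ccccc5)c5ccccc45)sc3c2)CC1` is the parent with an unsubstituted benzyl group on the indole nitrogen. In a functional assay on MDA-MB-231 cells (Homo sapiens) for cytotoxicity, read by MTT assay, with a stated time of 72 h (a lower number here means a stronger inhibitor, a higher number a weaker inhibitor), compound 2 gives 2850 nM, the higher of the two numbers recorded so far. Its nearest neighbour is compound 1 `CC1CCN(Cc2ccc3nc(NC(=O)N/N=C/c4cn(Cc5cccc(Cl)c5)c5ccccc45)sc3c2)CC1`, which carries a chloro group on the benzyl ring and in this assay gives 2110 nM; the step of a 1.4-fold higher number from compound 1 to compound 2 (0.13 log units; within the scatter) lies within the scatter, so the two cannot be ordered.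

Compound 3 `CC1CCN(Cc2ccc3nc(NC(=O)N/N=C/c4cn(Cc5ccc(Cl)cc5)c5ccccc45)sc3c2)CC1` is the target here. Relative to compound 2 the change is chloro in place of hydrogen on an aromatic carbon. Within the data shown here, the only comparison that bears on it is the one pair above, where removing a chloro group from the same benzyl ring, at another aromatic carbon, moved the number by a 1.4-fold higher number from compound 1 to compound 2 (0.13 log units; within the scatter), within the scatter. Placing chloro para to a large group is therefore expected to give at most a small shift, toward a lower number if anything, and the step from compound 2 to compound 3 is estimated as a 1.3-fold lower number from compound 2 to compound 3 (0.11 log units; within the scatter). Compound 3 is expected to give 2200 nM in this assay, with a range of 1100 nM to 4500 nM.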

Compound 3, half-maximal inhibitory concentration: 2850 nM
Estimate against measurement, compound 3: 1.3-fold (0.11 log units) below; the range from low to high includes it.
By their numbers in this assay, from the lowest: compounds 1, 2 and 3 (each within the scatter of the next).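

Notes on the benzyl ring: in this assay the step to 4-chlorobenzyl from benzyl gives no change at the digits printed from compound 2 to compound 3 (within the scatter), so chloro on this aromatic carbon, para to a large group, gives no reading apart from the unsubstituted parent. Comparing the two chloro placements gives a 1.4-fold higher number from compound 1 to compound 3 (0.13 log units; within the scatter), so the 4-chlorophenyl and 3-chlorophenyl forms cannot be ordered, and all three compounds now form a single group within the scatter. No supporting data are available to account for these readings.

What stays open is whether a group of a different kind at this para position, such as an amine, a carboxylic acid or a longer chain, would move the number beyond the scatter, since chloro is the only replacement for hydrogen shown here. Also open, going by these compounds, is whether the two chloro placements would still read alike with a change elsewhere on the shared core, or in a cell assay on another line.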